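This account rests on a few compounds, and the source may have more. Where it says the series, first, only, none or still open, it means among the compounds named here.

Compound 1 `COc1ccc(CN(C(=O)CCl)c2cc(OC)c(OC)c(OC)c2)cc1O` gives the lowest number of the two measured in a functional assay on MGC-803 cells (Homo sapiens) for inhibition, read by MTT assay, with a stated time of 48 h (on this read-out lower numbers stand for stronger inhibition and higher numbers for weaker inhibition), at 84 nM. Compound 2 `COc1ccc(N(Cc2cc(OC)c(OC)c(OC)c2)C(=O)CCl)cc1O` stands far higher in this assay at 24500 nM; the two structures differ in more than one place, so the pair only shows the gap. Compound 3 `COc1ccc(CN(C(=O)C[Se]C#N)c2cc(OC)c(OC)c(OC)c2)cc1O` differs from compound 1 by a group of 3 heavy atoms (1 carbon, 1 nitrogen, 1 selenium; no ring) in place of one chlorine atom, on a saturated chain carbon bound to a carbonyl carbon. For the measured compounds named here, no measured pair reports this kind of change; with compound 1 at 84 nM as the only anchor, the step is expected to be small, at most about the scatter, in either direction, a 1.4-fold lower number from compound 1 to compound 3 (0.15 log units; within the scatter). Compound 3 is estimated at 60 nM, within 15 nM to 300 nM.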

Compound 3, half-maximal inhibitory concentration: 270 nM
For compound 3 the middle estimate is 4.5-fold (0.65 log units) below the measured one, within the range that was stated.
By their numbers in this assay, from the lowest: compound 1; then compound 3; then compound 2.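

This position tolerates replacement of the chloro group: in this assay, compound 3 still gives 270 nM without the chlorine atom. Placing the group of 3 heavy atoms containing selenium on the saturated chain carbon bound to a carbonyl carbon nevertheless costs potency, with a 3.2-fold higher number from compound 1 to compound 3 (0.51 log units; beyond the scatter). For the compounds shown here, this is the first single-place comparison, and no available evidence accounts for the step. The compounds shown leave open how a bromine atom, an amine or a longer chain would read at this position.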